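The source may hold more compounds than are shown below. What is called first, only, known or untested is meant among the compounds shown, and "the series" means these compounds.

Of the compounds shown here, three have been measured in a functional assay on THP-1 cells (Homo sapiens) for inhibition, read by sulforhodamine B assay, tested at 10 uM; on this read-out lower numbers stand for less inhibition of growth and higher numbers for more inhibition of growth at the one concentration tested. Compound 1 `CC(=O)N1N=C(c2ccc(OCc3cn(Cc4ccc([N+](=O)[O-])cc4)nn3)cc2)CC1c1ccccc1` gives 0%. Compound 2 `COc1cc(C2CC(c3ccc(OCc4cn(Cc5ccc([N+](=O)[O-])cc5)nn4)cc3)=NN2C(C)=O)ccc1Oc1cn(Cc2ccc([N+](=O)[O-])cc2)nn1` gives 0%. Compound 3 `COc1cc(C2CC(c3ccc(Br)cc3)=NN2C(C)=O)ccc1OCc1cn(Cc2ccc([N+](=O)[O-])cc2)nn1` gives 1%, a number that sits within the usual scatter of both compound 1 and compound 2; on the numbers shown the three compounds cannot be told apart, and all of them show no growth inhibition worth the name. For the measured compounds named here, no pair of measured compounds differs in one place only, so no single step can be read off within the measured set.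

Compound 4 `COc1cc(C2CC(c3cccc4ccccc34)=NN2C(C)=O)ccc1OCc1cn(Cc2ccc([N+](=O)[O-])cc2)nn1` has not been measured. It differs from compound 3 by naphthalen-1-yl in place of 4-bromophenyl on a carbon with a double bond to nitrogen. Going by the values given here, this exchange at the carbon with a double bond to nitrogen has no measured counterpart. The expected step from compound 3 to compound 4 is a number 2 percentage points higher from compound 3 to compound 4 (within the scatter), none beyond the scatter, because compound 3 gives 1% and the two other measured compounds sit at the same level. Compound 4 is therefore estimated to give 3%, within a range from 0% to 15%.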

Compound 4, percent growth inhibition at one concentration: 10%
Beside the measured number, compound 4's estimate is 7 percentage points below it, and the stated range covers the measured number.
By their numbers in this assay, from the lowest: compounds 1, 2, 3 and 4 (each within the scatter of the next).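

In this assay, for the compounds shown here, naphthalen-1-yl in place of 4-bromophenyl gives a number 9 percentage points higher from compound 3 to compound 4 (within the scatter) and is the first one-place exchange that can be read. At this carbon with a double bond to nitrogen, replacing a single six-membered aromatic ring bearing bromine with two fused-count aromatic rings of carbon only does not separate the two compounds on this read-out. No measurement on hand accounts for the step.

As far as these compounds go, whether an amine or a carboxylic acid on this carbon would give a number beyond the scatter of compound 3 remains open. Also open, from the compounds shown here alone, is whether compound 3 and compound 4 would stay within the scatter of each other at any concentration other than the single one tested.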